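The source may report more compounds than this note shows. Statements on the series, on what has been measured and on what is new or still open speak of the compounds shown alone.

Compound 1 `COc1ccc(/C=C/C(=O)OCCCCOc2cc(Cl)ccc2Oc2ccc(Cl)cc2Cl)cc1OC` gives 73400 nM in an ADME assay on U-937 cells (Homo sapiens) for cytotoxicity, read by MTT assay, with a stated time of 72 h (a lower number here means that less compound is tolerated, a higher number that more compound is tolerated), the lower of the two numbers in hand. Compound 2 `O=C(/C=C/c1ccc(O)c(O)c1)OCCCCCCCCCCCCOc1cc(Cl)ccc1Oc1ccc(Cl)cc1Cl` gives 174000 nM in this assay, a gap that lies beyond the usual scatter. Compound 3 `O=C(/C=C/c1ccc(O)c(O)c1)OCCCCOc1cc(Cl)ccc1Oc1ccc(Cl)cc1Cl` is the next member to be run; against compound 1 it carries 3,4-dihydroxyphenyl in place of 3,4-dimethoxyphenyl on a double-bonded chain carbon bound to a double-bonded chain carbon. Going by the values given here, no pair differing only in this place has been measured, so the size of the step is uncertain; a small upward move, near the edge of the scatter, is expected, a 1.4-fold higher number from compound 1 to compound 3 (0.13 log units; within the scatter). Compound 3 is therefore expected to give 100000 nM, with a range from 40000 nM to 250000 nM.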

Compound 3, concentration lethal to 50% of the cells: 12000 nM
The estimate for compound 3 lay 8.3-fold (0.92 log units) above the measured number; measured number outside the range, below it.
By their numbers in this assay, from the lowest: compound 3; then compound 1; then compound 2.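

Going by these compounds alone, changing 3,4-dimethoxyphenyl to 3,4-dihydroxyphenyl on a double-bonded chain carbon bound to a double-bonded chain carbon gives the first measured step at this place: in this assay, a 6.1-fold lower number from compound 1 to compound 3 (0.79 log units; beyond the scatter). The place is therefore not silent, and here less compound is tolerated with the 3,4-dihydroxyphenyl group, which brings hydrogen-bond donors that the 3,4-dimethoxyphenyl group lacks. No measurement in hand accounts for the step.

From the compounds shown here alone, this remains a single pair, so it is open whether the step carries over to other chains. Going by these compounds, how an amine or a carboxylic acid at this place would read is also open.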